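Three halogen patterns, and a trichlorophenyl still to come

This account rests on a few compounds, and the source may have more. Where it says the series, first, only, none or still open, it means among the compounds named here.

Measured in a functional assay on MKN-45 cells (Homo sapiens) for antiproliferative activity, read by CellTiter-Glo, with a stated time of 3 days; a higher number here means a weaker inhibitor, a lower number a stronger inhibitor:
Compound 1 (`CC(Oc1c(N)ncc2c(-c3cnn(C4CCNCC4)c3)coc12)c1c(Cl)cccc1Cl`) 2000 nM
Compound 2 (`CC(Oc1c(N)ncc2c(-c3cnn(C4CCNCC4)c3)coc12)c1c(Cl)c(F)cc(F)c1Cl`) 480 nM
Compound 3 (`CC(Oc1c(N)ncc2c(-c3cnn(C4CCNCC4)c3)coc12)c1c(Br)ccc(F)c1Cl`) 510 nM

Compound 3 stands level with compound 2 at the lower end of these numbers: a 1.1-fold higher number from compound 2 to compound 3 (0.03 log units; within the scatter), while a 3.9-fold lower number from compound 1 to compound 3 (0.59 log units; beyond the scatter). Compound 4 (`CC(Oc1c(N)ncc2c(-c3cnn(C4CCNCC4)c3)coc12)c1c(Cl)cc(Cl)cc1Cl`) is not yet measured. Its change is a group of 9 heavy atoms (6 carbon, 3 chlorine; one six-membered aromatic ring of carbon only) in place of a group of 9 heavy atoms (6 carbon, 1 fluorine, 1 chlorine, 1 bromine; one six-membered aromatic ring of carbon only), on a saturated chain carbon bound to an oxygen on an aromatic ring and a saturated chain carbon, and the group that enters is 2,4,6-trichlorophenyl. The steps that bear on it are a 4.2-fold lower number from compound 1 to compound 2 (0.62 log units; beyond the scatter) and the modest step to compound 3 given above. Both groups that lowered the number of compound 1 are larger than its own, as the entering group is. In this assay no step beyond the scatter is therefore expected. The estimated step is a 1.3-fold higher number from compound 3 to compound 4 (0.11 log units; within the scatter). For compound 4 the expected value is 650 nM, within an estimated range of 250 nM to 1700 nM.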

Compound 4, half-maximal inhibitory concentration: 3600 nM
For compound 4 the middle estimate is 5.5-fold (0.74 log units) below the measured one; measured number above the stated range.
By their numbers in this assay, from the lowest: compounds 2 and 3 (each within the scatter of the next); then compounds 1 and 4 (each within the scatter of the next).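

In this assay, a larger group on this saturated chain carbon does not by itself lower the number: the 2,4,6-trichlorophenyl group gives a 7.1-fold higher number from compound 3 to compound 4 (0.85 log units; beyond the scatter) and a 7.5-fold higher number from compound 2 to compound 4 (0.88 log units; beyond the scatter). The added chloro on an aromatic carbon gives only a 1.8-fold higher number from compound 1 to compound 4 (0.26 log units; within the scatter), so the gain seen earlier does not extend to this added halogen. Among these compounds, only the two groups carrying fluorine sit at the lower numbers. No measurement available here accounts for this difference. Going by these compounds, how a methoxy or an amine on this aromatic ring would read remains open, as does whether fluorine alone would lower the number.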